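Variation at the acetoxymethyl carbon of compound 1

The source may report more compounds than this note shows. Statements on the series, on what has been measured and on what is new or still open speak of the compounds shown alone.

Measured compounds:
compound 1 `CC(=O)OC/C1=C/C[C@](C)(CCC=C(C)C)/C=C/[C@@H](OC(=O)C=C(C)C)[C@](C)(O)/C=C/C1=O`: 4510 nM
compound 2 `CC(C)=CCC[C@]1(C)/C=C/[C@@H](OC(=O)C=C(C)C)[C@](C)(O)/C=C/C(=O)/C(C=O)=C\C1`: 12600 nM
compound 3 `CC(C)=CCC[C@]1(C)/C=C/[C@@H](OC(=O)C=C(C)C)[C@](C)(O)/C=C/C(=O)/C(C(=O)O)=C\C1`: 16100 nM

In a functional assay on MCF7 cells (Homo sapiens) for antiproliferative activity, read by MTT assay, with a stated time of 48 h (a lower number here means a stronger inhibitor, a higher number a weaker inhibitor), compound 1 gives the lowest of the three numbers. Its nearest neighbour is compound 2, with a 2.8-fold higher number from compound 1 to compound 2 (0.45 log units; beyond the scatter), and compound 3 is furthest, with a 3.6-fold higher number from compound 1 to compound 3 (0.55 log units; beyond the scatter); between those two there is a 1.3-fold higher number from compound 2 to compound 3 (0.11 log units; within the scatter). Both measured steps from compound 1 keep the shared core and alter only the group on the double-bonded ring carbon, and both read as modest losses.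

Compound 4 `CC(C)=CCC[C@]1(C)/C=C/[C@@H](OC(=O)C=C(C)C)[C@](C)(O)/C=C/C(=O)/C(CN2CCN(C)CC2)=C\C1` is not yet measured. It differs from compound 1 as follows: 4-methylpiperazin-1-yl in place of acetoxy on a saturated chain carbon bound to a double-bonded ring carbon. Among the measured compounds shown here, no measured pair exchanges the acetoxy part while keeping the saturated chain carbon, so the steps from compound 1 to compound 2 and from compound 1 to compound 3 are the only ones bearing on this position. They are of a different kind, yet they suggest that any departure from acetoxymethyl here has so far cost a little. A modest loss, or no change beyond the scatter, is therefore expected. For compound 4 the expected step is a 1.7-fold higher number from compound 1 to compound 4 (0.22 log units; within the scatter). Compound 4 is estimated to give 7500 nM in this assay, with a range from 2500 nM to 22000 nM.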

Compound 4, half-maximal inhibitory concentration: 550 nM
Compound 4: the middle estimate sits 14-fold (1.13 log units) above what was measured, and the stated range ends above it.
By their numbers in this assay, from the lowest: compound 4; then compound 1; then compounds 2 and 3 (each within the scatter of the next).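

In this assay this position no longer reads as one where any departure from acetoxymethyl costs a little: exchanging acetoxy for 4-methylpiperazin-1-yl on the saturated chain carbon gives an 8.2-fold lower number from compound 1 to compound 4 (0.91 log units; beyond the scatter) and is the only change shown that moves the number downward from compound 1. Set against the other replacements on the double-bonded ring carbon, (4-methylpiperazin-1-yl)methyl gives a 23-fold lower number from compound 2 to compound 4 (1.36 log units; beyond the scatter) and a 29-fold lower number from compound 3 to compound 4 (1.47 log units; beyond the scatter) so the group at this one place spans a much wider range than formyl and carboxy alone suggested. Nothing measured here accounts for the gain, and its origin within the exchange remains unassigned.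

Morpholin-4-yl, piperidin-1-yl, dimethylamino or an unsubstituted piperazin-1-yl on the same saturated chain carbon would show whether the gain is specific to 4-methylpiperazin-1-yl or extends to other amines. Open as well are a plain hydroxy in place of acetoxy on that carbon, which would give a reference for the acetoxy group itself, and a longer chain carrying the same amine.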